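The source may hold more compounds than are shown below. What is called first, only, known or untested is meant among the compounds shown, and "the series" means these compounds.

Working notes on the series. Three compounds have numbers in a functional assay on DU-145 cells (Homo sapiens) for inhibition, read by trypan blue exclusion, with a stated time of 72 h; a lower number here means a stronger inhibitor, a higher number a weaker inhibitor. Compound 1 `Cn1c(=O)c(S(=O)(=O)c2ccc(F)cc2)cc2cnc(Nc3ccc4occc4c3)nc21` gives 5000 nM there. Compound 2 `Cn1c(=O)c(S(=O)(=O)c2ccc(F)cc2F)cc2cnc(Nc3ccc4occc4c3)nc21` gives 15000 nM in this assay, and compound 3 `Cn1c(=O)c(C(=O)Nc2ccc(F)cc2F)cc2cnc(Nc3ccc4[nH]ccc4c3)nc21` gives 5000 nM. Compound 2 therefore gives the highest number of the three; both compound 1 and compound 3 sit lower by the same margin, and both gaps are beyond the scatter.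

Going by the values given here, the one single-point step available is a 3.0-fold higher number from compound 1 to compound 2 (0.48 log units; beyond the scatter), with fluoro in place of hydrogen on an aromatic carbon. It touches a different part of the molecule from the change now in question.

Compound 4 `Cn1c(=O)c(S(=O)(=O)c2ccc(F)cc2F)cc2cnc(Nc3ccncn3)nc21` differs from compound 2 as follows: pyrimidin-4-yl in place of 1-benzofuran-5-yl on a nitrogen on an aromatic ring. Among the compounds with values here, no measured pair shows this exchange or one resembling it, and compound 3 differs from compound 1 in more than one place, so it gives no single-point reading either. Within the data shown here, the expectation for this assay therefore rests on compound 2 alone, with no step to lean on, and no direction beyond the scatter can be argued from the data.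

The estimate for compound 4 in this assay is 15000 nM, with a range from 4000 nM to 50000 nM. This corresponds to an expected step of no change at the digits printed from compound 2 to compound 4 (within the scatter), centred on no change beyond the scatter.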

Compound 4, half-maximal inhibitory concentration: 50000 nM
Compound 4: the middle estimate sits 3.3-fold (0.52 log units) below what was measured; measured number inside the range.
By their numbers in this assay, from the lowest: compounds 1 and 3 (each within the scatter of the next); then compound 2; then compound 4.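

Going by these compounds alone, replacing 1-benzofuran-5-yl with pyrimidin-4-yl on the nitrogen gives the first reading at this position in this assay: there is a 3.3-fold higher number from compound 2 to compound 4 (0.52 log units; beyond the scatter), so the group here is not neutral to the read-out, and this exchange moves toward a weaker inhibitor. The two single-point steps now available, a 3.0-fold higher number from compound 1 to compound 2 (0.48 log units; beyond the scatter) and the step above, lie at different places on the molecule, and both run toward a higher number, so neither of the two changes improves on its parent in this assay. Nothing measured on these compounds accounts for the step, and the numbers here describe only the cell read-out.

The exchange changes several things at once: one ring replaces two, the ring size and count of heavy atoms fall, and ring nitrogens replace the furan oxygen, and this single pair cannot separate these differences. A phenyl or a pyridin-3-yl on the same nitrogen would help to divide them, and a benzofuran bearing an amine or a carboxylic acid would show whether the larger group tolerates further substitution.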